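Removing one chloro group from the sulfone-bearing ring

The source may hold more compounds than are shown below. What is called first, only, known or untested is meant among the compounds shown, and "the series" means these compounds.

Compound 1 `CC1CCN(c2c(S(=O)(=O)c3ccc(Cl)cc3)cnc3cc(Cl)ccc23)CC1` gives 91% in an assay on isolated protein for displacement of a labelled ligand from metabotropic glutamate receptor 5 (Homo sapiens), with a stated time of 60 min, tested at 1 uM; on this read-out higher numbers stand for more inhibition at the one concentration tested (going by the name of the read-out) and lower numbers for less inhibition.
Compound 2 `CC1CCN(c2c(S(=O)(=O)c3ccc(F)c(Cl)c3)cnc3c(F)cccc23)CC1` gives 95% in this assay.
Compound 3 `CC1CCN(c2c(S(=O)(=O)c3ccc(Cl)c(Cl)c3)cnc3cc(Cl)ccc23)CC1` gives 89% in this assay.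

All three compounds share the same core with a piperidine and a sulfone. Compound 1 and compound 3 differ in one place: hydrogen in place of chloro on an aromatic carbon. That change gave a number 2 percentage points higher from compound 3 to compound 1 (within the scatter), so the two values are indistinguishable. Compound 2 and compound 3 differ in more than one place, and the difference between their cores is not broken down here.

Compound 4 `CC1CCN(c2c(S(=O)(=O)c3ccc(F)cc3)cnc3c(F)cccc23)CC1` has not been measured in this assay. It differs from compound 2 by hydrogen in place of chloro on an aromatic carbon. The place is not identical to the earlier change: there the leaving chloro sat ortho to a chloro group, here it sits ortho to a fluoro group, so this is the same kind of change rather than the same change. Because the earlier change gave a number 2 percentage points higher from compound 3 to compound 1 (within the scatter), the step from compound 2 to compound 4 is expected to be a number 4 percentage points lower from compound 2 to compound 4 (within the scatter). Compound 4 is therefore estimated at 91%, expected to lie between 76% and 99%.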

Compound 4, a percentage reported as inhibition, at one concentration (the size of the read-out at that concentration, not a potency): 26%
Compound 4: the middle estimate sits 65 percentage points above what was measured, and the stated range ends above it.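

On the core of compound 2, swapping 3-chloro-4-fluorophenyl for 4-fluorophenyl in this assay gave a number 69 percentage points lower from compound 2 to compound 4 (beyond the scatter). The effect of replacing this chloro with hydrogen therefore did not carry from one core to the other, as the two pairs side by side make clear: the same change on two cores in this assay, a number 2 percentage points higher (within the scatter) from compound 3 to compound 1 and a number 69 percentage points lower (beyond the scatter) from compound 2 to compound 4, 71 percentage points apart, beyond the scatter of two such steps. This shows that the same kind of change can leave the reading unresolved on one core and lower it sharply on another, but it does not show why, and two pairs cannot separate the role of the rest of the core from that of the other halogen on the ring, a fluoro group in compound 2 and a chloro group in compound 3.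

The compounds shown leave open whether chlorine itself matters on the core of compound 2, or whether a methyl, a methoxy or a nitrile in the same place would give a reading like that of compound 2. They also leave open how an amine or a carboxylic acid at that position would read.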